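Methoxy in place of acetoxymethyl: expected plasma exposure

The compounds below may be only part of what the source reports. "The series", "measured", "known", "first", "only" and "open" are said of these compounds alone.

In an in vivo ADME assay on the whole organism (plasma) for pharmacokinetics, with Rattus norvegicus as the target, at a dose of 50 mg/kg by the oral route (a lower number here means less compound in the circulation, a higher number more compound in the circulation at the dose given), compound 1 `Cc1cc(C)c(NC(=O)c2sccc2S(=O)(=O)Nc2onc(C)c2Cl)c(C)c1` gives 81600 nM, compound 2 `Cc1cc(C)c(NC(=O)c2sccc2S(=O)(=O)Nc2onc(C)c2Cl)c(C)c1CO` gives 5110 nM and compound 3 `CC(=O)OCc1c(C)cc(C)c(NC(=O)c2sccc2S(=O)(=O)Nc2onc(C)c2Cl)c1C` gives 7420 nM. Compound 3 stands second of the three numbers, but its step from the hydroxymethyl analogue, a 1.5-fold higher number from compound 2 to compound 3 (0.16 log units; within the scatter), does not separate the two. Compound 4 `COc1c(C)cc(C)c(NC(=O)c2sccc2S(=O)(=O)Nc2onc(C)c2Cl)c1C` carries methoxy in place of acetoxymethyl on an aromatic carbon, on the same aromatic carbon. Both measured substituents there gave large drops from hydrogen: a 16-fold lower number from compound 1 to compound 2 (1.20 log units; beyond the scatter) and an 11-fold lower number from compound 1 to compound 3 (1.04 log units; beyond the scatter). Methoxy itself has not been measured, so the expectation stays near the lower pair, with wide uncertainty towards compound 1. The expected step is a 1.6-fold higher number from compound 3 to compound 4 (0.21 log units; within the scatter), a slight rise that stays within the scatter. Compound 4 is estimated at 12000 nM, with an expected range of 3500 nM to 45000 nM.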

Compound 4, maximal plasma concentration: 8510 nM
For compound 4 the middle estimate is 1.4-fold (0.15 log units) above the measured one; the range from low to high includes it.
By their numbers in this assay, from the lowest: compounds 2, 3 and 4 (each within the scatter of the next); then compound 1.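

In this assay, methoxy on this aromatic carbon also falls well short of hydrogen, with a 9.6-fold lower number from compound 1 to compound 4 (0.98 log units; beyond the scatter), so all three oxygen-bearing groups shown lower the number beyond the scatter. The steps of a 1.1-fold higher number from compound 3 to compound 4 (0.06 log units; within the scatter) and a 1.7-fold higher number from compound 2 to compound 4 (0.22 log units; within the scatter) do not separate methoxy from either group, even though methoxy has 2 heavy atoms and acetoxymethyl 5. Nothing available explains this shared drop. Open, as far as these compounds go, is whether a group without oxygen, such as an amine or an ethyl chain, would keep the number near that of compound 1.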